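The source may hold more compounds than are shown below. What is called first, only, known or untested is meant among the compounds shown, and "the series" means these compounds.

In a functional assay on MCF7 cells (Homo sapiens) for inhibition, read by MTT assay, with a stated time of 3 days (a lower number here means a stronger inhibitor, a higher number a weaker inhibitor), compound 3 (`CCOC(=O)[C@H](CS(=O)(=O)O)NCC(=O)NNC(=O)COc1ccc(-c2nc3ccccc3s2)cc1OC`) gives 1990 nM, within the scatter of compound 1 (`CC[C@H](C)[C@@H](NCC(=O)NNC(=O)COc1ccc(-c2nc3ccccc3s2)cc1OC)C(=O)O`) at 1790 nM, while compound 2 (`COc1cc(-c2nc3ccccc3s2)ccc1OCC(=O)NNC(=O)CN1CCC[C@H]1C(=O)O`) gives 840 nM. Compound 4 (`CCOC(=O)[C@@H]1CCCN1CC(=O)NNC(=O)COc1ccc(-c2nc3ccccc3s2)cc1OC`) has 2-(ethoxycarbonyl)pyrrolidin-1-yl in place of (1-(ethoxycarbonyl)-2-sulfoethyl)amino on a saturated chain carbon bound to a carbonyl carbon. The closest evidence is a 2.4-fold higher number from compound 2 to compound 3 (0.37 log units; beyond the scatter), where 2-carboxypyrrolidin-1-yl leaves. Also relevant are a 2.1-fold lower number from compound 1 to compound 2 (0.33 log units; beyond the scatter), where it enters, and a 1.1-fold higher number from compound 1 to compound 3 (0.05 log units; within the scatter), which stays within the scatter. For the measured compounds named here, no measured step compares ethoxycarbonyl with carboxy on that ring, so the expectation stays loose. A modest move to a lower number in this assay is expected, a 2.1-fold lower number from compound 3 to compound 4 (0.32 log units; beyond the scatter). For compound 4 the estimate is 950 nM, with an expected range of 420 nM to 2100 nM.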

Compound 4, half-maximal inhibitory concentration: 770 nM
The estimate for compound 4 lay 1.2-fold (0.09 log units) above the measured number; the measured number falls inside the stated range.
By their numbers in this assay, from the lowest: compounds 4 and 2 (each within the scatter of the next); then compounds 1 and 3 (each within the scatter of the next).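

In this assay ethyl in place of hydrogen on an oxygen next to a carbonyl group gives a 1.1-fold lower number from compound 2 to compound 4 (0.04 log units; within the scatter) and so leaves 2-(ethoxycarbonyl)pyrrolidin-1-yl and 2-carboxypyrrolidin-1-yl indistinguishable at this position. Both open-chain amino groups now lie on the higher side of the ring-bearing ester, with a 2.6-fold lower number from compound 3 to compound 4 (0.41 log units; beyond the scatter) and a 2.3-fold lower number from compound 1 to compound 4 (0.37 log units; beyond the scatter), and none of these four compounds goes against that split. No measurement shown accounts for these steps.

As far as these compounds go, whether the lower numbers follow the ring or its substituent stays open. Unsubstituted pyrrolidin-1-yl, a piperidin-1-yl ring or a carboxamide on the ring would bear on this.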